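Pyridinylethoxy in place of hydroxypropoxy on the sulfonamide

The source may hold more compounds than are shown below. What is called first, only, known or untested is meant among the compounds shown, and "the series" means these compounds.

Compound 3 `CC(=O)SCC(=O)c1ccc(NS(=O)(=O)c2ccc(OCCCO)cc2)nc1` has no single number in a functional assay on U226 cells (Homo sapiens) for cytotoxicity; a lower number here means that less compound is needed, a higher number that more compound is needed for the effect; its entry reads "not determined" (no result reported). Compound 2 `COc1ccc(S(=O)(=O)Nc2ccc(C(=O)CSC(C)=O)cn2)cc1` stands the same way, with "not determined" (no result reported). Within the data shown here, the only number comes from compound 1 `CC(=O)SCC(=O)c1ccc(NS(=O)(=O)c2ccc(OCCCCN(C)C)cc2)nc1`, which gives 120 nM in this assay. Compound 4 `CC(=O)SCC(=O)c1ccc(NS(=O)(=O)c2ccc(OCCc3ccccn3)cc2)nc1`, still to be measured, differs from compound 3 by pyridin-2-yl in place of hydroxymethyl on a saturated chain carbon, two bonds along the chain from an oxygen on an aromatic ring. Among the measured compounds shown here, with compound 3 holding no number, no direction for this step can be drawn from the data, and a step of any size in this assay remains possible; the one anchor is compound 1. Compound 4 is therefore expected to come in near 150 nM, within a wide range from 40 nM to 600 nM.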

Compound 4, half-maximal effective concentration: 9600 nM
The estimate for compound 4 lay 64-fold (1.81 log units) below the measured number, and the stated range ends below it.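

The chain end at this position is not a neutral choice: pyridin-2-yl in place of 2-(dimethylamino)ethyl, on a saturated chain carbon, two bonds along the chain from an oxygen on an aromatic ring, gives an 80-fold higher number from compound 1 to compound 4 (1.90 log units; beyond the scatter) in this assay. No measurement shown bears on the reason for this step. Steps to compound 2 and compound 3 cannot be read, since neither holds a number. From the compounds shown here alone, whether a morpholine, a carboxylic acid or a shorter dimethylamino chain at this place would read closer to compound 1 or to compound 4 stays open.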